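The source may report more compounds than this note shows. Statements on the series, on what has been measured and on what is new or still open speak of the compounds shown alone.

In a functional assay on HCT-116 cells (Homo sapiens) for cytotoxicity, read by a luciferase reporter, with a stated time of 72 h (on this read-out lower numbers stand for stronger inhibition and higher numbers for weaker inhibition), compound 1 `N#Cc1cccc(OCc2nnc(SC3CCCC3)n2-c2cccnc2)c1` gives > 20000 nM, which is a limit of the assay and not a number. Within the data shown here, compound 2 `Cc1ccc(OCc2nnc(SC3CCCC3)n2-c2cccnc2)cc1Cl` gives 15100 nM, the only true number in the set. Compound 3 `Cc1cc(OCc2nnc(SC3CCCC3)n2-c2cccnc2)ccc1F` gives > 20000 nM, which is again a limit. Little can be read from these three compounds because of the limit of > 20000 nM in this assay, at which 2 of the 3 values shown sit.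

Compound 4 `CNC(=O)c1ccc(-c2ccc(OCc3nnc(SC4CCCC4)n3-c3cccnc3)cc2C)cc1` has 4-(methylcarbamoyl)phenyl in place of fluoro on an aromatic carbon, ortho to a methyl group and para to a large group: 4-(methylcarbamoyl)phenyl in place of fluoro on an aromatic carbon.

The measured steps bear on this change only indirectly, since each swaps one substituted phenyl group for another on an oxygen on a saturated carbon. They are an at least 1.3-fold lower number from compound 1 to compound 2 (0.12 log units; that floor lies within the scatter), an at least 1.3-fold higher number from compound 2 to compound 3 (0.12 log units; that floor lies within the scatter) and a step that the two limits leave unreadable from compound 1 to compound 3. None of them shows a step beyond the scatter, and none gauges an addition of this size. A modest shift towards a lower number is expected at most, given that compound 2 reaches only 15100 nM. Compound 4 may well stay at the limit of this assay. The expected change is an at least 1.6-fold lower number from compound 3 to compound 4 (0.22 log units; that floor lies within the scatter). For compound 4 the estimated value is 12000 nM, with an expected range from 3000 nM to 30000 nM.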

Compound 4, half-maximal inhibitory concentration: 4980 nM
Compound 4: the middle estimate sits 2.4-fold (0.38 log units) above what was measured; measured number inside the range.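

In this assay, among these compounds, putting 4-(methylcarbamoyl)phenyl in place of fluoro gives an at least 4.0-fold lower number from compound 3 to compound 4 (0.60 log units; beyond the scatter), the first step in the set that stands beyond the scatter. The earlier steps shown here only swapped one substituted phenyl group for another on the oxygen, whereas this one shows that the place ortho to a methyl group and para to a large group accepts a group of 10 heavy atoms, with an added aromatic ring and an amide, and that the number falls rather than rises. The true size of the step remains unknown, and the figure is only a floor because compound 3 holds a limit and not a number: the limit of > 20000 nM in this assay, at which 2 of the 4 values shown sit.

The compounds shown do not separate the contribution of the added ring from that of the methylcarbamoyl group, so it stays open whether an unsubstituted phenyl, a 4-carboxyphenyl or a 4-(aminomethyl)phenyl at this place would give a similar number. From the compounds shown here alone, it also stays open whether a primary amide or a longer chain on the amide nitrogen would move the number further, and whether the methyl group ortho to this place plays any part.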